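Halogen swap in a series fixed at the assay limit

The compounds below may be only part of what the source reports. "The series", "measured", "known", "first", "only" and "open" are said of these compounds alone.

Compound 1 `O=c1ccoc2cc(OCc3cn(Cc4ccccc4Br)nn3)ccc12` gives > 100000 nM in a functional assay on A549 cells (Homo sapiens) for cytotoxicity, read by MTT assay, with a stated time of 48 h (on this read-out higher numbers stand for weaker inhibition and lower numbers for stronger inhibition), which is a limit of the assay.
Compound 2 `O=c1ccoc2cc(OCc3cn(Cc4cccc(Br)c4)nn3)ccc12` gives > 100000 nM in this assay, again a limit of the assay.
Compound 3 `O=c1ccoc2cc(OCc3cn(Cc4ccc(F)cc4)nn3)ccc12` gives > 100000 nM in this assay, once more a limit of the assay.

Compound 3 therefore stands only at a limit, as do the two other measured compounds; none of the three yields a number. Compound 4 `O=c1ccoc2cc(OCc3cn(Cc4ccc(Br)cc4)nn3)ccc12` differs from compound 3 by bromo in place of fluoro on an aromatic carbon. Among the measured compounds shown here, three measured steps bear on this kind of change: a step that the two limits leave unreadable from compound 1 to compound 2, a step that the two limits leave unreadable from compound 1 to compound 3 and a step that the two limits leave unreadable from compound 2 to compound 3. Each of them runs between two limits, so none of them reveals how shifting a halogen to another ring carbon or trading one halogen for another moves the read-out. What the measured compounds do share is the limit of > 100000 nM in this assay, at which 3 of the 3 values shown sit. On that basis compound 4 is expected to remain at the same limit rather than give a number, and the expected step of a number no higher from compound 3 to compound 4 (the limit leaves the size open) is only a nominal one that the assay will most likely not resolve. The estimate for compound 4 is 100000 nM, with a range from 30000 nM to 300000 nM.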

Compound 4, half-maximal inhibitory concentration: > 100000 nM
Compound 4: a limit, no number; the forecaster's own chance of this, stated with the estimate: 85%; the middle value lies on the limit itself.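

Compound 4 adds no readable step to compound 1, compound 2 or compound 3, because each pair joins two limits: the limit of > 100000 nM in this assay, at which 4 of the 4 values shown sit.

The compounds shown leave open whether the kind of halogen or its place on the phenyl ring moves the read-out at all.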